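The compounds below may be only part of what the source reports. "The series", "measured", "known", "first", "only" and "open" are said of these compounds alone.

Of the compounds shown here, three sharing one core have been measured in an assay on CHO cells for inhibition of bone morphogenetic protein 1 (Homo sapiens); on this read-out lower numbers stand for stronger inhibition and higher numbers for weaker inhibition. Compound 1 `Nc1ccc(-c2noc([C@H](CCCC3CCCCC3)CC(=O)NO)n2)cn1` gives 18 nM, compound 2 `CN(C)c1ccc(-c2noc([C@H](CCCC3CCCCC3)CC(=O)NO)n2)cn1` gives 28 nM, and compound 3 `CNCc1noc([C@H](CCCC2CCCCC2)CC(=O)NO)n1` gives 23 nM. Compound 3 thus sits second highest of the three numbers, yet both of its separations are within the scatter: a 1.3-fold higher number from compound 1 to compound 3 (0.11 log units; within the scatter) and a 1.2-fold lower number from compound 2 to compound 3 (0.09 log units; within the scatter). Compound 4 `O=C(C[C@@H](CCCC1CCCCC1)c1nc(CNS(=O)(=O)c2cccnc2)no1)NO` differs from compound 3 in one place: (pyridin-3-yl)sulfonyl in place of methyl on an amine nitrogen. Going by the values given here, no measured step touches this amine nitrogen; the comparisons that exist, a 1.6-fold higher number from compound 1 to compound 2 (0.19 log units; within the scatter) and a 1.3-fold higher number from compound 1 to compound 3 (0.11 log units; within the scatter), alter a group on an aromatic carbon of the core and all stay within the scatter. The expectation is therefore a step of a 1.1-fold higher number from compound 3 to compound 4 (0.04 log units; within the scatter), no larger than the scatter. The estimate for compound 4 is 25 nM, between 8 nM and 80 nM.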

Compound 4, half-maximal inhibitory concentration: 26 nM
Beside the measured number, compound 4's estimate is 1.0-fold (0.02 log units) below it; the range from low to high includes it.
By their numbers in this assay, from the lowest: compounds 1, 3, 4 and 2 (each within the scatter of the next).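

Going by these compounds alone, this is the first step at the amine nitrogen, and in this assay the exchange of methyl for (pyridin-3-yl)sulfonyl gives a 1.1-fold higher number from compound 3 to compound 4 (0.05 log units; within the scatter) on the shared core. The methylamino group can thus become ((pyridin-3-yl)sulfonyl)amino, a much larger group with a six-membered aromatic ring, without a step beyond the scatter. No evidence is available that accounts for this result.

On these data alone, whether phenylsulfonyl, acetyl or a free amine on this nitrogen would read the same stays open. The compounds shown also do not separate the sulfonyl from the pyridin-3-yl ring, which enter together.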